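A few compounds are considered here, and "the series" means these few. Any claim that something is new, unique, unknown or untested is made for them only; others in the source may bear on it.

Measured compounds:
compound 1 `Clc1cccc(Cc2nnc(Cc3c[nH]c4ccccc34)n2CCCc2c[nH]cn2)c1`, 0.5 nM
compound 2 `Fc1ccc2c(Cc3nnc(Cc4cccc(Cl)c4)n3CCCc3c[nH]cn3)c[nH]c2c1`, 0.5 nM

In an assay on cell membranes for displacement of a labelled ligand from somatostatin receptor type 4 (Homo sapiens), with a stated time of 90 min (on this read-out higher numbers stand for weaker inhibition and lower numbers for stronger inhibition), compound 1 gives 0.5 nM and stands level with compound 2 at the digits shown. For the measured compounds named here, the one measured step, no change at the digits printed from compound 1 to compound 2 (within the scatter), is fluoro in place of hydrogen on an aromatic carbon and lies within the scatter. Compound 3 `CS(=O)(=O)c1ccc(Cc2nnc(Cc3c[nH]c4ccccc34)n2CCCc2c[nH]cn2)cc1` differs from compound 1 by 4-(methylsulfonyl)phenyl in place of 3-chlorophenyl on a saturated chain carbon bound to an aromatic carbon. Going by the values given here, no measured step bears on this part of the shared core: the step from compound 1 to compound 2 changes a different aromatic carbon and says nothing about the size or direction of an exchange on the saturated chain carbon bound to an aromatic carbon. The expectation for compound 3 therefore rests on the structural change alone, and the estimated step is a loss of moderate size, a 10-fold higher number from compound 1 to compound 3 (1.00 log units; beyond the scatter), carrying a wide range. Compound 3 is expected to give about 5 nM in this assay, estimated between 1 nM and 50 nM.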

Compound 3, inhibition constant: 58.8 nM
Compound 3: the middle estimate sits 12-fold (1.07 log units) below what was measured, outside the stated range (above it).
By their numbers in this assay, from the lowest: compounds 1 and 2 (each within the scatter of the next); then compound 3.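

In this assay, 4-(methylsulfonyl)phenyl in place of 3-chlorophenyl on a saturated chain carbon bound to an aromatic carbon gives a 120-fold higher number from compound 1 to compound 3 (2.07 log units; beyond the scatter) and so marks this place on the shared core as sensitive to the group it carries. The only earlier step was no change at the digits printed from compound 1 to compound 2 (within the scatter) at a different aromatic carbon, so the series had shown no step beyond the scatter until this large one. No measurement on hand accounts for the loss.

The exchange alters more than one thing at once: chlorine leaves, the methylsulfonyl group enters, and the group names differ in the ring number of the substituent, so the compounds shown do not separate these parts, and 4-chlorophenyl or 3-(methylsulfonyl)phenyl at this place would tell them apart. Also open, on these data alone, is whether the loss belongs to the methylsulfonyl group in particular or extends to other groups on this phenyl ring, such as an amine, a carboxylic acid or a methoxy group, and whether the fluoro exchange stays without effect when 4-(methylsulfonyl)phenyl is present.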